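Working notes: the step from compound 3 to compound 4

The compounds below may be only part of what the source reports. "The series", "measured", "known", "first", "only" and "open" are said of these compounds alone.

Measured compounds:
compound 1, `N#Cc1cnc(NCc2cnccc2C(F)(F)F)cc1N[C@H]1CC[C@@H](O)CC1`, 100 nM in an assay on isolated protein for inhibition of protein kinase C theta type (Homo sapiens), read by TR-FRET, with a stated time of 2 h; a higher number here means a weaker inhibitor, a lower number a stronger inhibitor
compound 2, `N#Cc1cnc(NCc2cnccc2C(F)(F)F)cc1NC[C@H]1CC[C@@H](O)CC1`, 58 nM in this assay
compound 3, `N#Cc1cnc(NCc2cnccc2C(F)(F)F)cc1NCCC1CCOCC1`, 1200 nM in this assay

Compound 3 carries the highest number of the three in this assay. Its distance to the others is set by a 12-fold higher number from compound 1 to compound 3 (1.08 log units; beyond the scatter) and by a 21-fold higher number from compound 2 to compound 3 (1.32 log units; beyond the scatter), both beyond the scatter, while a 1.7-fold lower number from compound 1 to compound 2 (0.24 log units; within the scatter) stays within it.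

Compound 4, `CNC(=O)[C@H]1CC[C@@H](Nc2cc(NCc3cnccc3C(F)(F)F)ncc2C#N)CC1`, is the next step: 4-(methylcarbamoyl)cyclohexyl in place of 2-(oxan-4-yl)ethyl on a nitrogen on an aromatic ring. Within the data shown here, two measured steps bear on it. Compound 1 also places a six-membered carbon ring directly on the aromatic nitrogen, and the step of a 12-fold higher number from compound 1 to compound 3 (1.08 log units; beyond the scatter) shows that exchanging that arrangement for the oxane-bearing chain raised the number strongly; a 21-fold higher number from compound 2 to compound 3 (1.32 log units; beyond the scatter) points the same way. Reversing that exchange is therefore expected to lower the number by a large amount. Among the measured compounds shown here, the 4-(methylcarbamoyl) group in place of the hydroxyl of compound 1 has no measured counterpart here, which widens the range. For compound 4 the expected step is a 12-fold lower number from compound 3 to compound 4 (1.08 log units; beyond the scatter), with an estimated 100 nM, between 30 nM and 400 nM.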

Compound 4, half-maximal inhibitory concentration: 27 nM
Compound 4: middle estimate off by 3.7-fold (0.57 log units), on the high side; the whole stated range lies above it.
By their numbers in this assay, from the lowest: compound 4; then compounds 2 and 1 (each within the scatter of the next); then compound 3.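

With methylcarbamoyl in place of hydroxy on a saturated ring carbon, a 3.7-fold lower number from compound 1 to compound 4 (0.57 log units; beyond the scatter) shows that the hydroxy group is not required for a low number in this assay and that this ring carbon accepts a larger group with a gain beyond the scatter. The change also gives a 2.1-fold lower number from compound 2 to compound 4 (0.33 log units; beyond the scatter), a modest step, while a 44-fold lower number from compound 3 to compound 4 (1.65 log units; beyond the scatter) is larger than either step that separated compound 3 from the hydroxy compounds, leaving compound 4 the strongest of the four inhibitors shown. No measurement here accounts for these differences.

As far as these compounds go, it remains open whether a dimethylcarbamoyl group, a carboxylic acid or an amine on that saturated ring carbon would keep the number as low. Also open, from the compounds shown here alone, is whether methylcarbamoyl would give a similar step on the (4-hydroxycyclohexyl)methyl arrangement of compound 2.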